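This account rests on a few compounds, and the source may have more. Where it says the series, first, only, none or still open, it means among the compounds named here.

Measured compounds:
compound 1 `COc1cc(OC)c(/C=C/S(=O)(=O)Nc2ccc(OC)c([N+](=O)[O-])c2)c(OC)c1` gives 2500 nM
compound 2 `COc1cc(OC)c(/C=C/S(=O)(=O)Nc2ccc(OC)c(N)c2)c(OC)c1` gives 5 nM
compound 3 `COc1ccc(NS(=O)(=O)/C=C/c2cc(OC)c(OC)c(OC)c2)cc1[N+](=O)[O-]` gives 75000 nM

All three were tested in a functional assay on DU-145 cells (Homo sapiens) for cytotoxicity, read by trypan blue exclusion, with a stated time of 96 h; on this read-out lower numbers stand for stronger inhibition and higher numbers for weaker inhibition. Compound 1 and compound 2 differ in one place, (amino in place of nitro on an aromatic carbon), and this change brought a 500-fold lower number from compound 1 to compound 2 (2.70 log units; beyond the scatter). Compound 3 has the same atoms as compound 1 joined differently; the difference between the two cores is not broken down here, and compound 3 stands at the highest number of the three, beyond the scatter from both others.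

Compound 4 `COc1ccc(NS(=O)(=O)/C=C/c2cc(OC)c(OC)c(OC)c2)cc1N` has not yet been measured. It differs from compound 3 by amino in place of nitro on an aromatic carbon, the same change as from compound 1 to compound 2, at a place described in identical words. On these data alone, the step is expected to be a 380-fold lower number from compound 3 to compound 4 (2.57 log units; beyond the scatter), slightly more cautious than the earlier one because the core of compound 3 is weaker and the transfer of a 500-fold lower number from compound 1 to compound 2 (2.70 log units; beyond the scatter) to it is untested. Compound 4 is therefore estimated at 200 nM, between 30 nM and 2000 nM.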

Compound 4, half-maximal inhibitory concentration: 35000 nM
Compound 4: middle estimate off by 180-fold (2.24 log units), on the low side, outside the stated range (above it).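

In this assay the change of amino in place of nitro on an aromatic carbon gave a 2.1-fold lower number from compound 3 to compound 4 (0.33 log units; beyond the scatter) and so kept its direction but not its earlier size. The size of this step therefore depended strongly on the core that carried it, as the two steps set side by side show: the same change on two cores in this assay, a 500-fold lower number (2.70 log units; beyond the scatter) from compound 1 to compound 2 and a 2.1-fold lower number (0.33 log units; beyond the scatter) from compound 3 to compound 4, 230-fold (2.37 log units) apart, beyond the scatter of two such steps This does not show which difference between the two cores accounts for the gap, and two pairs cannot predict the step on a further core.

The compounds shown leave open whether a hydroxyl or an acetamide at the same place would follow the amino or the nitro on either core. They also leave open whether the gap between the steps would hold in other cells.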